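Series notes: aryl on the piperazine nitrogen, compound 3 to 4

The source may hold more compounds than are shown below. What is called first, only, known or untested is meant among the compounds shown, and "the series" means these compounds.

The series shares one core, shown with compound 1 `Cc1cccc2sc(NC(=O)CCN3CCN(C4CCN(C)CC4)CC3)nc12`, and varies the group on an amine nitrogen in a ring of the piperazine. In an assay on membranes from liver for displacement of a labelled ligand from Sigma intracellular receptor 2 (Rattus norvegicus), read by scintillation counting, with a stated time of 120 min (a higher number here means a weaker inhibitor, a lower number a stronger inhibitor), compound 1 gives 3600 nM. Compound 2 `Cc1cccc2sc(NC(=O)CCN3CCN(CCN(C(C)C)C(C)C)CC3)nc12` gives 121 nM in this assay, so a 30-fold lower number from compound 1 to compound 2 (1.47 log units; beyond the scatter). Compound 3 `Cc1cccc2sc(NC(=O)CCN3CCN(c4ccccn4)CC3)nc12` carries pyridin-2-yl at that position. In this assay compound 3 reports only a limit, > 1000 nM. Because of that limit (the limit of > 1000 nM in this assay, at which 1 of the 3 values shown sits), the step that the limit leaves unreadable from compound 1 to compound 3, while an at least 8.2-fold higher number from compound 2 to compound 3 (0.91 log units; beyond the scatter). Within the numbers shown, compound 3 therefore stands at the weak end of the series, with no exact value.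

Compound 4 `Cc1cccc2sc(NC(=O)CCN3CCN(c4ncccn4)CC3)nc12` differs from compound 3 by one change, (pyrimidin-2-yl in place of pyridin-2-yl on an amine nitrogen in a ring). Within the data shown here, no measured pair swaps one aromatic group for another; the two steps that reach compound 3 both arrive from non-aromatic groups, and one is unreadable. Among the measured compounds shown here, there is thus no measured step that gives the direction or size of this change. The expectation is that the number stays near where compound 3 sits, a step that the limit leaves unreadable from compound 3 to compound 4 that is estimated to fall within the scatter, with a real chance that the assay again reports only a limit. Compound 4 is estimated at 3000 nM, in the range 1000 nM to 10000 nM.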

Compound 4, inhibition constant: > 1000 nM
Compound 4: only a limit was reported (the forecaster's own chance of this, stated with the estimate: 65%); the middle value lies beyond the limit too.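

In this assay, compound 4 also ends in a limit and not a number, so a second aromatic group on this amine nitrogen in a ring joins compound 3 at the same limit: the limit of > 1000 nM in this assay, at which 2 of the 4 values shown sit. Set against the 2-(diisopropylamino)ethyl group of compound 2, the pyrimidin-2-yl group gives an at least 8.2-fold higher number from compound 2 to compound 4 (0.91 log units; beyond the scatter), which extends the gap seen with pyridin-2-yl to a second aromatic ring, though compound 1 shows that a non-aromatic group can also give a weak number. The steps from compound 3 to compound 4 and from compound 1 to compound 4 cannot be read, so the added ring nitrogen of pyrimidin-2-yl has no measurable effect here, in either direction.

Open, from the compounds shown here alone, is whether a plain phenyl group at this position, or another aromatic ring, would give a readable number that places aromatic groups on a scale with compound 1. Also open, going by these compounds, is how much of the number for compound 2 depends on its diisopropylamino end, which a 2-(dimethylamino)ethyl group or a longer chain carrying the same amine would address.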